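The source may report more compounds than this note shows. Statements on the series, on what has been measured and on what is new or still open speak of the compounds shown alone.

Measured in a functional assay on HL-60 cells (Homo sapiens) for antiproliferative activity, with a stated time of 72 h; a higher number here means a weaker inhibitor, a lower number a stronger inhibitor:
- Compound 1 `COc1cc(OC)c(C(=O)/C=C/c2ccccc2Cl)c(O)c1CN(C)CC(=O)O`: 80300 nM
- Compound 2 `CCN(CC)Cc1c(OC)cc(OC)c(C(=O)/C=C/c2ccccc2Cl)c1O`: 30900 nM

For the measured compounds named here, compound 2, at 30900 nM, holds the lower of the two numbers so far, which makes it the stronger inhibitor of the pair. Compound 3 `COc1cc(OC)c(C(=O)/C=C/c2ccccc2Cl)c(O)c1CN(C)C` has not yet been measured. It differs from compound 2 in one place: dimethylamino in place of diethylamino on a saturated chain carbon bound to an aromatic carbon. Put simply, dimethylamino stands in place of diethylamino on a saturated chain carbon bound to an aromatic carbon. Going by the values given here, only one measured step bears on this place, a 2.6-fold lower number from compound 1 to compound 2 (0.41 log units; beyond the scatter). That step was modest, and it removed a carboxymethyl group, which the present change does not touch. A smaller step in this assay therefore seems likely, with at most a slight lean towards a higher number. For compound 3 the expected value is 40000 nM, with an estimated range from 16000 nM to 90000 nM. This estimate means a 1.3-fold higher number from compound 2 to compound 3 (0.11 log units; within the scatter), so no expected change beyond the scatter.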

Compound 3, half-maximal inhibitory concentration: 19200 nM
Compound 3: the middle estimate sits 2.1-fold (0.32 log units) above what was measured; the range from low to high includes it.
By their numbers in this assay, from the lowest: compounds 3 and 2 (each within the scatter of the next); then compound 1.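

Replacing diethylamino with dimethylamino on the saturated chain carbon gives a 1.6-fold lower number from compound 2 to compound 3 (0.21 log units; within the scatter) in this assay, so the two small amines cannot be told apart in this assay. The other pairing is more informative: compound 1 and compound 3 differ only by hydrogen in place of carboxy, and a 4.2-fold lower number from compound 1 to compound 3 (0.62 log units; beyond the scatter) shows what that single change does, whereas the earlier step from compound 1 changed the rest of the amine as well. No measurement offered here explains either result.

The compounds shown leave open whether a ring amine such as piperidine or morpholine, or a primary amine, would fit the same picture at this place. They also leave open how a methyl ester in place of the carboxylic acid would compare with compound 1.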